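The source may hold more compounds than are shown below. What is called first, only, known or untested is meant among the compounds shown, and "the series" means these compounds.

Working notes on the cytotoxicity series

Three compounds carry measurements in a functional assay on HT-1080 cells (Homo sapiens) for cytotoxicity, read by MTT assay, with a stated time of 72 h; a lower number here means a stronger inhibitor, a higher number a weaker inhibitor. Compound 3 `COc1ccc(Cn2nc(-c3ccccc3)c3cc(C(=N)Nc4ccc(N5CCN(C)CC5)cc4)nc(NC4CCCCC4)c32)cc1` gives 640 nM in this assay. Compound 1 `COc1ccc(Cn2nc(-c3ccccc3)c3cc(C(=N)Nc4ccccc4)nc(NC4CCCCC4)c32)cc1` gives 3400 nM in this assay. Compound 2 `COc1ccc(Cn2ncc3cc(C(=N)Nc4ccc(N5CCN(C)CC5)cc4)ncc32)cc1` gives 5300 nM in this assay; its number stands within the scatter of that of compound 1 and well apart from that of compound 3.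

Within the measured set one single-point change is available: compound 1 differs from compound 3 as follows.
hydrogen in place of 4-methylpiperazin-1-yl on an aromatic carbon
This change gave a 5.3-fold higher number from compound 3 to compound 1 (0.73 log units; beyond the scatter).

Compound 4 `COc1ccc(Cn2ncc3cc(C(=N)Nc4ccccc4)ncc32)cc1` is not yet measured in this assay. It differs from compound 2 by the same change:
hydrogen in place of 4-methylpiperazin-1-yl on an aromatic carbon
The two place lines match word for word, so this is the same change made on a different core. How the core of compound 2 differs from that of compound 3 is not broken down here; the two cores differ by a large part of the molecule.

Expectation for compound 4: since the only precedent, the step from compound 3 to compound 1 a 5.3-fold higher number from compound 3 to compound 1 (0.73 log units; beyond the scatter), points to a higher number when the 4-methylpiperazin-1-yl group leaves, a step of similar direction and size is expected from compound 2 to compound 4 a 3.8-fold higher number from compound 2 to compound 4 (0.58 log units; beyond the scatter). As far as these compounds go, the core of compound 2 already gives a higher number than compound 3, and it is unknown whether the step carries over unchanged on this core, so the range is kept wide. Compound 4 is therefore estimated at 20000 nM in this assay, within 7000 nM to 60000 nM.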

Compound 4, half-maximal inhibitory concentration: 25700 nM
Beside the measured number, compound 4's estimate is 1.3-fold (0.11 log units) below it; measured number inside the range.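

In this assay, replacing 4-methylpiperazin-1-yl with hydrogen on the aromatic carbon gave a 4.8-fold higher number from compound 2 to compound 4 (0.69 log units; beyond the scatter), and this step agrees with the one seen on the other core: the same change on two cores in this assay, a 5.3-fold higher number (0.73 log units; beyond the scatter) from compound 3 to compound 1 and a 4.8-fold higher number (0.69 log units; beyond the scatter) from compound 2 to compound 4, 1.1-fold (0.04 log units) apart, within the scatter of two such steps
Across these two cores, which differ by a large part of the molecule, the change therefore carried over in both direction and size. This rests on two matched pairs only: it does not show that the step would hold on any further core, and it does not show which part of the 4-methylpiperazin-1-yl group accounts for the step, as the whole group is exchanged for hydrogen in both pairs.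

The compounds shown leave open whether a morpholine ring, a dimethylamino group or a carboxylic acid on the same aromatic carbon would give a number closer to that of the 4-methylpiperazin-1-yl compounds or to that of the hydrogen compounds. As far as these compounds go, the separate contributions of the parts in which the two cores differ also remain open.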